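Acetoxy to methoxy on the shared core

A few compounds are considered here, and "the series" means these few. Any claim that something is new, unique, unknown or untested is made for them only; others in the source may bear on it.

In a functional assay on A549 cells (Homo sapiens) for inhibition, with a stated time of 48 h, tested at 30 uM (on this read-out lower numbers stand for less inhibition of growth and higher numbers for more inhibition of growth at the one concentration tested), compound 1 (`C=C[C@@](C)(/C=C/c1ccc(OC(C)=O)cc1)CCC=C(C)C`) gives 60%, the higher of the two measured numbers, and compound 2 (`C=C[C@@](C)(/C=C/c1ccc(OC(=O)CCCCCCCCC)cc1)CCC=C(C)C`) gives 33%. Compound 3 (`C=C[C@@](C)(/C=C/c1ccc(OC)cc1)CCC=C(C)C`) has methyl in place of acetyl on an oxygen on an aromatic ring. Going by the values given here, the only measured step, a number 27 percentage points lower from compound 1 to compound 2 (beyond the scatter), lies beyond the scatter, but it places octyl on the chain and keeps the carbonyl, so it bears only indirectly. Among the compounds with values here, no measured step removes the carbonyl. Only a small downward step, possibly within the scatter, is expected: a number 8 percentage points lower from compound 1 to compound 3 (within the scatter). The estimated value for compound 3 is 52%, ranging from 30% to 75%.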

Compound 3, percent growth inhibition at one concentration: 34%
Compound 3: middle estimate off by 18 percentage points, on the high side; the measured number falls inside the stated range.
By their numbers in this assay, from the lowest: compounds 2 and 3 (each within the scatter of the next); then compound 1.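

In this assay, methyl in place of acetyl on an oxygen on an aromatic ring gives a number 26 percentage points lower from compound 1 to compound 3 (beyond the scatter). This is the first step shown that removes the carbonyl at this position, and the acetyl does not pass to methyl without a loss of growth inhibition at the one concentration tested. Nothing measured here speaks to the reason for this step.

Open: whether a free hydroxyl or a propanoyl group on the same oxygen would stay near compound 1 at 60%. Also open, on these data alone, is whether the carbonyl alone accounts for the step.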